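Working notes: methoxy in place of nitro

The source may report more compounds than this note shows. Statements on the series, on what has been measured and on what is new or still open speak of the compounds shown alone.

Measured in an ADME assay on HepG2 cells (Homo sapiens) for cytotoxicity, with a stated time of 72 h (a lower number here means that less compound is needed, a higher number that more compound is needed for the effect), so far:
compound 1 `CCc1ccc(NC(=O)Nc2cc(C)nc3ccccc23)cc1` gives 17000 nM as a number
compound 2 `Cc1cc(NC(=O)Nc2cccc([N+](=O)[O-])c2)c2ccccc2n1` gives > 25000 nM as a limit
compound 3 `Cc1ccc(NC(=O)Nc2cc(C)nc3ccccc23)cc1` gives > 25000 nM as a limit

Compound 2 stands at > 25000 nM which is a limit and not a number. Compound 2 sits with compound 3 on the limit of > 25000 nM in this assay, at which 2 of the 3 values shown sit, and no size of step can be read from that limit.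

Compound 4 `COc1cccc(NC(=O)Nc2cc(C)nc3ccccc23)c1` differs from compound 2 as follows: methoxy in place of nitro on an aromatic carbon. Within the data shown here, no measured step covers this exchange. Among the measured compounds shown here, the only measured step, an at least 1.4-fold higher number from compound 1 to compound 3 (0.16 log units; that floor lies within the scatter) concerns a different place, and its floor lies within the scatter. It gives no size or direction for the present change.

For the measured compounds named here, compound 1 at 17000 nM is the one number in this assay and shows that a value can be read. No step beyond the scatter is therefore expected, and a report of the limit alone is thought more likely than not. The expected step is an at least 1.0-fold lower number from compound 2 to compound 4 (0.01 log units; that floor lies within the scatter) and it is an estimate with no firm direction. For compound 4 the estimate is 24000 nM with an expected range from 11000 nM to 45000 nM in this series.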

Compound 4, half-maximal effective concentration: > 25000 nM
Compound 4: a limit, no number (the forecaster's own chance of this, stated with the estimate: 60%); at least 1.0-fold (0.01 log units) between middle value and limit.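

In this assay compound 2 and compound 4 both give a limit and not a number, so no step can be read for methoxy in place of nitro on an aromatic carbon: the limit of > 25000 nM in this assay, at which 3 of the 4 values shown sit.

The compounds shown leave open the size and direction of this exchange in this assay, with only compound 1 giving a number.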